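One Chloro Fewer: Expecting a Modest Loss of Potency

This account rests on a few compounds, and the source may have more. Where it says the series, first, only, none or still open, it means among the compounds named here.

Among the compounds with values here, compound 1 `CCO/C(O)=C1\C(COCCn2ccnn2)=NC(C)=C(C(=O)OC)C1c1cccc(Cl)c1Cl` gives the lower of the two known numbers in a functional assay (aorta) with Rattus norvegicus as the target (on this read-out higher numbers stand for weaker inhibition and lower numbers for stronger inhibition), at 5.01 nM. Compound 2 `CCO/C(O)=C1\C(COCCN2CC(=O)N=C2N)=NC(C)=C(C(=O)OC)C1c1ccccc1Cl`, which differs from it in several places, gives 20 nM in this assay, a gap beyond the usual scatter. Compound 3 `CCO/C(O)=C1\C(COCCn2ccnn2)=NC(C)=C(C(=O)OC)C1c1ccccc1Cl` has not been measured; it differs from compound 1 by hydrogen in place of chloro on an aromatic carbon. Within the data shown here, no measured pair shows this exact change, so the expectation rests on compound 1 alone. A modest weakening is expected, with the step of a 2.4-fold higher number from compound 1 to compound 3 (0.38 log units; beyond the scatter) lying just beyond the scatter. Compound 3 is therefore expected to give about 12 nM in this assay, within a range from 4 nM to 40 nM.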

Compound 3, half-maximal inhibitory concentration: 15.9 nM
Compound 3: middle estimate off by 1.3-fold (0.12 log units), on the low side; low and high end bracket the measured number.
By their numbers in this assay, from the lowest: compound 1; then compounds 3 and 2 (each within the scatter of the next).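

In this assay, going from 2,3-dichlorophenyl to 2-chlorophenyl gives a 3.2-fold higher number from compound 1 to compound 3 (0.50 log units; beyond the scatter), so this one chloro accounts for a modest but real part of the potency of compound 1. With 2-chlorophenyl held constant, exchanging the five-membered ring on the side chain gives a 1.3-fold lower number from compound 2 to compound 3 (0.10 log units; within the scatter), so these two rings cannot be told apart here. Nothing at hand explains the effect of the chloro. Going by these compounds, whether a fluoro, methyl or methoxy group on this aromatic carbon would serve as well as chloro remains open, as does whether the chloro step keeps its size with the other side-chain ring.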